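The source may report more compounds than this note shows. Statements on the series, on what has been measured and on what is new or still open speak of the compounds shown alone.

Compound 1 `CCOC(=O)N1CCC(=NNC(=O)c2ccc(Cl)cc2)CC1`: in a toxicity assay on BJ cells (Homo sapiens) for cytotoxicity, read by MTT assay, with a stated time of 24 h (on this read-out higher numbers stand for weaker inhibition and lower numbers for stronger inhibition), compound 1 gives only the limit > 400000 nM.
Compound 2 `O=C(NN=C1CC(c2ccccc2)NC(c2ccccc2)C1)c1ccccc1`: in this assay compound 2 gives only the limit > 400000 nM.
Compound 3 `O=C(NN=C1CC(c2ccccc2)NC(c2ccccc2)C1)c1ccc(Cl)cc1`: in this assay compound 3 gives only the limit > 400000 nM.

Every value shown so far in this assay is a limit and not a number, as the limit of > 400000 nM in this assay, at which 3 of the 3 values shown sit, records. Within the data shown here, compound 3 therefore stands nowhere on a scale: its entry is the same limit that compound 1 and compound 2 reach, and the one step that can be traced, a step that the two limits leave unreadable from compound 2 to compound 3, is unreadable because both of its ends sit at the limit.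

Compound 4 `O=C(NN=C1CC(c2ccccc2)NC(c2ccccc2)C1)c1ccc(F)cc1` differs from compound 3 in one place: fluoro in place of chloro on an aromatic carbon. Among the measured compounds shown here, no measured step speaks to this exchange; the only step on the shared core, from compound 2 to compound 3, leaves its size hidden between two limits. Since compound 1, compound 2 and compound 3 all end at the limit in this assay, no direction or size of change can be drawn from them, and compound 4 is expected to return the same limit, that is a step of a number no higher from compound 3 to compound 4 (the limit leaves the size open). On that basis compound 4 is estimated at 400000 nM, within a range from 150000 nM to 1000000 nM, most probably reported as a limit rather than a number.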

Compound 4, half-maximal inhibitory concentration: > 400000 nM
Compound 4 was reported as a limit; the forecaster's own chance of this, stated with the estimate: 85%; the middle value lies on the limit itself.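

In this assay compound 4 gives only the limit > 400000 nM, and the steps among compound 2, compound 3 and compound 4 cannot be read, as every compound shown ends at the same limit: the limit of > 400000 nM in this assay, at which 4 of the 4 values shown sit. As far as these compounds go, whether hydrogen, chloro or fluoro on that aromatic carbon changes the read-out at all, and in which direction, remains open.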